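A Methylsulfanyl Addition on a Series Without Measurable Cytotoxicity

A few compounds are considered here, and "the series" means these few. Any claim that something is new, unique, unknown or untested is made for them only; others in the source may bear on it.

Measured compounds:
compound 1, `CCCCC[Se]c1nc(N)c2ccccc2n1`: > 100000 nM
compound 2, `CCCCC[Se]c1nc(NCc2ccccc2)c2ccccc2n1`: > 100000 nM

In a functional assay on CCRF-CEM cells (Homo sapiens) for cytotoxicity, read by MTT assay, with a stated time of 72 h (a lower number here means that less compound is tolerated, a higher number that more compound is tolerated), compound 1 gives > 100000 nM, which is a limit of the assay rather than a number. Compound 2 gives > 100000 nM, also a limit. The step that the two limits leave unreadable from compound 1 to compound 2 therefore cannot be read. Compound 3, `CCCCC[Se]c1nc(NCc2ccc(SC)cc2)c2ccccc2n1`, differs from compound 2 by methylsulfanyl in place of hydrogen on an aromatic carbon. For the measured compounds named here, no measured step bears on this change, and both values shown sit at the limit of > 100000 nM in this assay, at which 2 of the 2 values shown sit. Compound 3 is therefore expected to show a step that the limit leaves unreadable from compound 2 to compound 3. For compound 3 the expected value is 120000 nM, ranging from 40000 nM to 300000 nM, most probably again reported as a limit.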

Compound 3, concentration lethal to 50% of the cells: > 100000 nM
Compound 3: no number, only a limit; the forecaster's own chance of this, stated with the estimate: 75%; the middle value lies beyond the limit too.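

For the compounds shown here, compound 2 and compound 3 each give only a limit of the assay, not a number, so no step between them can be read in this assay. The compounds shown leave open whether methylsulfanyl in place of hydrogen changes cytotoxicity at all.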